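Removing the Acyl Group from the Pyrrolidine Ring Nitrogen

The compounds below may be only part of what the source reports. "The series", "measured", "known", "first", "only" and "open" are said of these compounds alone.

Compound 1 `CC(C)C(=O)N1CCC[C@H]1C(=O)N1CCC(NS(=O)(=O)c2cc(S(=O)(=O)c3ccccc3)ccc2C(F)(F)F)CC1`: 100000 nM
Compound 2 `CC(C)(C)CC(=O)N1CCC[C@H]1C(=O)N1CCC(NS(=O)(=O)c2cc(S(=O)(=O)c3ccccc3)ccc2C(F)(F)F)CC1`: 25000 nM

In a physicochemical assay for solubility (on this read-out higher numbers stand for higher solubility and lower numbers for lower solubility), compound 2 stands lowest of the two numbers shown; its nearest neighbour, compound 1, lies higher by a 4.0-fold lower number from compound 1 to compound 2 (0.60 log units; beyond the scatter). Compound 3 `CN1CCC[C@H]1C(=O)N1CCC(NS(=O)(=O)c2cc(S(=O)(=O)c3ccccc3)ccc2C(F)(F)F)CC1` has not been measured. It differs from compound 2 by methyl in place of neopentylcarbonyl on an amine nitrogen in a ring. Within the data shown here, the one measured step, a 4.0-fold lower number from compound 1 to compound 2 (0.60 log units; beyond the scatter), concerns the same carbonyl group that now disappears altogether, so a shift in the same direction as compound 1 seems plausible. Compound 3 is expected to give 150000 nM, in a range of 40000 nM to 500000 nM, a step of a 6.0-fold higher number from compound 2 to compound 3 (0.78 log units; beyond the scatter).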

Compound 3, solubility: 100000 nM
Compound 3: middle estimate off by 1.5-fold (0.18 log units), on the high side, within the range that was stated.
By their numbers in this assay, from the lowest: compound 2; then compounds 1 and 3 (each within the scatter of the next).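

In this assay, methyl in place of neopentylcarbonyl on this amine nitrogen in a ring gives a 4.0-fold higher number from compound 2 to compound 3 (0.60 log units; beyond the scatter), whereas methyl in place of isopropylcarbonyl gives no change at the digits printed from compound 1 to compound 3 (within the scatter). The carbonyl at this position can therefore be lost altogether without a step beyond the scatter from the isopropylcarbonyl compound, and of the three compounds only the neopentylcarbonyl compound stands apart. Nothing measured here explains this difference. The compounds shown leave open how a plain hydrogen, a longer alkyl chain or an acetyl group on this nitrogen would read on this scale.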